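The source may hold more compounds than are shown below. What is called first, only, known or untested is meant among the compounds shown, and "the series" means these compounds.

Measured compounds:
compound 1 `Cc1n[nH]cc1-c1cc2c(s1)C(=O)N[C@]1(CC[C@@](O)(c3ccc(F)cc3)CC1)N2`, 130 nM
compound 2 `CC1(C)NC(=O)c2cc(-c3ccncc3)sc2N1`, 100 nM
compound 3 `CC1(C)Nc2cc(-c3ccncc3)sc2C(=O)N1Cc1ccccc1`, 1.5 nM

In an assay for inhibition of Rho-associated protein kinase 1 (Homo sapiens), read by TR-FRET, with stated times of 5 min and 2 h (a higher number here means a weaker inhibitor, a lower number a stronger inhibitor), compound 3 gives 1.5 nM, the lowest of the three numbers. Compound 2 gives 100 nM and compound 1 gives 130 nM; both gaps to compound 3 lie beyond the usual scatter, so compound 3 is the strongest inhibitor of the three as measured.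

The next compound, compound 4 `CC1(C)NC(=O)c2sc(-c3ccncc3)cc2N1`, has not yet been run in this assay. Its change from compound 3 is hydrogen in place of benzyl on an amide-type nitrogen in a ring. For the measured compounds named here, no pair of measured compounds isolates this single change, so there is no measured step to lean on. Going by the values given here, the only pointer is compound 2, which also carries a hydrogen on its amide-type nitrogen in a ring and gives 100 nM in this assay, though its core is not that of compound 4, so the comparison is loose.

Taking the shared feature with compound 2 as a guide, the expected step in this assay from compound 3 to compound 4 is a clear weakening, beyond the scatter, of about a 53-fold higher number from compound 3 to compound 4 (1.73 log units; beyond the scatter). Compound 4 is estimated at 80 nM, with a range from 20 nM to 300 nM.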

Compound 4, half-maximal inhibitory concentration: 90 nM
For compound 4 the middle estimate is 1.1-fold (0.05 log units) below the measured one; measured number inside the range.
By their numbers in this assay, from the lowest: compound 3; then compounds 4, 2 and 1 (each within the scatter of the next).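

Hydrogen in place of benzyl on the amide-type nitrogen in a ring gives, in this assay, a 60-fold higher number from compound 3 to compound 4 (1.78 log units; beyond the scatter), a large step and the first measured one at this position. Within this single pair, the low number goes with the benzyl group and is lost with the hydrogen, so this nitrogen, two ring bonds from the ring nitrogen, is a place where the substituent matters strongly; one pair supports no wider pattern. Nothing measured here explains why the number moves so far with this change.

Open, as far as these compounds go, is how much of the benzyl group is needed: a methyl group, a longer chain such as phenethyl, or a benzyl carrying an amine or a carboxylic acid on its aromatic ring could each hold the number close to that of compound 3 or let it return towards that of compound 4. Also open, from the compounds shown here alone, is whether a benzyl group on the amide-type nitrogen of the core of compound 2 would give a step of similar size.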